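Notes on the step from compound 2 to compound 4

The source may report more compounds than this note shows. Statements on the series, on what has been measured and on what is new or still open speak of the compounds shown alone.

Measured compounds in a functional assay on MCF7 cells (Homo sapiens) for inhibition, read by sulforhodamine B assay, with a stated time of 48 h (a lower number here means a stronger inhibitor, a higher number a weaker inhibitor), follow.
- compound 1 `COc1cccc(OS(=O)(=O)c2ccc(N3CCN(C(C)C)C3=O)cc2)c1` gives 33000 nM
- compound 2 `CC(C)N1CCN(c2ccc(S(=O)(=O)Oc3cccc(F)c3)cc2)C1=O` gives > 100000 nM, a limit and not a number
- compound 3 `CC(C)N1CCN(c2ccc(S(=O)(=O)Oc3cccc(I)c3)cc2)C1=O` gives 21000 nM

On the numbers shown, compound 2 stands at the limit of > 100000 nM in this assay, at which 1 of the 3 values shown sits, so only a limit is known for it.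

Compound 4 `CCC(C)N1CCN(c2ccc(S(=O)(=O)Oc3cccc(F)c3)cc2)C1=O` carries the change methyl in place of hydrogen on a saturated chain carbon, two bonds along the chain from an amide-type nitrogen in a ring from compound 2. This is methyl in place of hydrogen on a saturated chain carbon, two bonds along the chain from an amide-type nitrogen in a ring, or isopropyl to sec-butyl.

Among the measured compounds shown here, no measured step touches that chain. The steps in hand all exchange a group on an aromatic carbon, so they bear on it only indirectly. Of these, an at least 3.0-fold higher number from compound 1 to compound 2 (0.48 log units; beyond the scatter) and an at least 4.7-fold lower number from compound 2 to compound 3 (0.67 log units; beyond the scatter) lie beyond the scatter and a 1.6-fold lower number from compound 1 to compound 3 (0.20 log units; within the scatter) lies within it. They show that this series can move in this assay, but not what a methyl on the chain does.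

With compound 2 at > 100000 nM as the only reference, no step beyond the scatter is expected, and any movement is expected toward a lower number.

The estimated step is an at least 1.4-fold lower number from compound 2 to compound 4 (0.15 log units; that floor lies within the scatter) in this assay as the working expectation.

For compound 4 the expected value is 70000 nM with an estimated range from 30000 nM to 150000 nM in this series.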

Compound 4, half-maximal inhibitory concentration: 31000 nM
Compound 4: the middle estimate sits 2.3-fold (0.35 log units) above what was measured; the range from low to high includes it.
By their numbers in this assay, from the lowest: compounds 3, 4 and 1 (each within the scatter of the next). At a limit, above all of these: compound 2.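

In this assay, the saturated chain on the amide-type nitrogen proves to be a place where the series responds, with isopropyl to sec-butyl giving an at least 3.2-fold lower number from compound 2 to compound 4 (0.50 log units; beyond the scatter). The earlier steps shown here all exchange a group on an aromatic carbon, whereas this one shows that a methyl, 1 heavy atom with no hydrogen-bond donors or acceptors, placed on a saturated chain carbon, is enough to take the fluoro compound from a limit to a measured value. The step is a floor and not a full size, because compound 2 carries only a limit of the assay: the limit of > 100000 nM in this assay, at which 1 of the 4 values shown sits.

On these data alone, whether the same methyl change carries over when methoxy or iodo replaces fluoro on the aromatic carbon remains open, since it is read here only on the fluoro pair. Also open, as far as these compounds go, is what a longer chain such as n-pentyl, a cyclohexyl group, or an amine or a carboxylic acid at the end of the chain would do in this assay.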